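Benzylsulfanyl ring chloro substitution in a dihydropyrimidine amide series

The source may hold more compounds than are shown below. What is called first, only, known or untested is meant among the compounds shown, and "the series" means these compounds.

All compounds share one core and are read in a functional assay on the whole organism (artery, strain albino) with Rattus norvegicus as the target, with a stated time of 30 min, at a dose of 10 mg/kg by the oral route; a lower number here means less inhibition, a higher number more inhibition at the dose given (going by the name of the read-out). Compound 1 `CC1=C(C(=O)Nc2ccc(F)cc2)C(c2ccc([N+](=O)[O-])cc2)N=C(SCc2ccccc2)N1` gives 7.2% in this assay. Compound 2 `CC1=C(C(=O)Nc2ccc(F)cc2)C(c2ccc([N+](=O)[O-])cc2)N=C(SCc2ccc(Cl)cc2)N1` carries the change chloro in place of hydrogen on an aromatic carbon relative to compound 1, and in this assay compound 2 gives 6.7%. The step of a number 0.5 percentage points lower from compound 1 to compound 2 (within the scatter) is therefore flat, and neither compound can be said to inhibit more than the other at this dose.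

Compound 3 `CC1=C(C(=O)Nc2ccc(Br)cc2)C(c2ccc(Cl)cc2Cl)N=C(SCc2ccccc2)N1` differs from compound 1 in more than one place; the difference between the two cores is not broken down here. In this assay compound 3 gives 3.6%, a number that sits within the scatter of both compound 1 and compound 2, so the three measured compounds are indistinguishable in this read-out.

Compound 4 `CC1=C(C(=O)Nc2ccc(Br)cc2)C(c2ccc(Cl)cc2Cl)N=C(SCc2ccccc2Cl)N1` is yet to be measured. Relative to compound 3 it carries the change (chloro in place of hydrogen on an aromatic carbon). This is the same kind of change as that from compound 1 to compound 2, but not the same: there the chloro enters para to a large group, here it enters ortho to a large group. Given that the one measured instance of this kind of change, a number 0.5 percentage points lower from compound 1 to compound 2 (within the scatter), stayed within the scatter, and that compound 3 already gives 3.6%, the expected step for compound 4 is a number 0.4 percentage points higher from compound 3 to compound 4 (within the scatter). Compound 4 is estimated at 4% in this assay, expected to fall between -3% and 12%.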

Compound 4, a percentage reported as inhibition, in the whole organism at one dose (the size of the read-out at that dose, not a potency): 5.7%
Compound 4: the middle estimate sits 1.7 percentage points below what was measured, within the range that was stated.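

In this assay, the change from benzylsulfanyl to (2-chlorobenzyl)sulfanyl on the core of compound 3, with the chloro ortho to a large group, reads as a number 2.1 percentage points higher from compound 3 to compound 4 (within the scatter), so this second instance of the change is also flat. Set beside the first instance, the two steps do not differ, and on the two cores shown the change carries over as an absence of any readable step: the same change on two cores in this assay, a number 0.5 percentage points lower (within the scatter) from compound 1 to compound 2 and a number 2.1 percentage points higher (within the scatter) from compound 3 to compound 4, 2.6 percentage points apart, within the scatter of two such steps. Among the compounds shown here, this does not show that a chloro effect transfers from one core to another, since neither step gives an effect to transfer; with only two steps and the chloro placed differently in each, any influence of the core cannot be separated from that of position, and a single oral dose says nothing about potency.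

Going by these compounds, it remains open whether anything on the benzyl group can move this read-out beyond the scatter, for instance an amine or a carboxylic acid on its aromatic ring, or a longer chain in place of the benzyl on sulfur. Also open, on these data alone, is how the same chloro placement would read on both cores, which would separate core from position.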